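The source may hold more compounds than are shown below. What is called first, only, known or untested is meant among the compounds shown, and "the series" means these compounds.

Measured in a physicochemical assay for lipophilicity, read by HPLC; a higher number here means a more lipophilic compound, a lower number a more polar compound:
- compound 1 `O=S(=O)(CS(=O)(=O)C(F)(F)F)c1ccc(OC(F)(F)F)cc1`: 2.2
- compound 2 `O=S(=O)(CS(=O)(=O)C(F)(F)F)c1ccc(F)cc1`: 1.3
- compound 3 `O=S(=O)(CS(=O)(=O)C(F)(F)F)c1ccc(Cl)cc1`: 1.9

The chloro member stands at the upper end of this small set: a number 0.30 log units lower from compound 1 to compound 3 (within the scatter), and a number 0.60 log units higher from compound 2 to compound 3 (beyond the scatter). The next structure is compound 4 `O=S(=O)(CS(=O)(=O)C(F)(F)F)c1ccc(C(F)(F)F)cc1`, with the change (trifluoromethyl in place of chloro on an aromatic carbon), trifluoromethyl in place of chloro on an aromatic carbon. The swap between the trifluoromethoxy and chloro members bears most closely on it and stayed within the scatter. The fluoro member stands apart: a number 0.90 log units lower from compound 1 to compound 2 (beyond the scatter). No step beyond the scatter is expected in this assay, and the estimated step is a number 0.10 log units higher from compound 3 to compound 4 (within the scatter). For compound 4 the estimate is 2, with an expected range of 1.7 to 2.4.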

Compound 4, partition coefficient: 1
The estimate for compound 4 lay 1.00 log units above the measured number; the whole stated range lies above it.
By their numbers in this assay, from the lowest: compounds 4 and 2 (each within the scatter of the next); then compounds 3 and 1 (each within the scatter of the next).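

In this assay, on this aromatic carbon para to a large group, trifluoromethyl does not fall with chloro or trifluoromethoxy (a number 0.90 log units lower from compound 3 to compound 4 (beyond the scatter)) (a number 1.20 log units lower from compound 1 to compound 4 (beyond the scatter)), and the second of these is the largest step in the set. Instead it stays within the scatter of fluoro (a number 0.30 log units lower from compound 2 to compound 4 (within the scatter)), which divides the four compounds into two pairs. Nothing available accounts for this division. Going by these compounds, whether an amine, a carboxylic acid or a longer chain here would join either pair remains open. So does whether the same division holds on another core.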